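Two flipped ring stereocentres and their expected effect on exposure

The compounds below may be only part of what the source reports. "The series", "measured", "known", "first", "only" and "open" are said of these compounds alone.

Values measured in an ADME assay on the whole organism (Mus musculus, strain C57BL/6) for pharmacokinetics, read by HPLC, with a stated time of 6 h, at a dose of 25 mg/kg by the oral route; a lower number here means less compound in the circulation, a higher number more compound in the circulation at the dose given:
compound 1 `O=C(O)[C@H](CO)NC(=O)[C@H]1C[C@H](O)CN1` gives 4010 nM
compound 2 `O=C(O)[C@@H](CO)NC(=O)[C@H]1C[C@@H](O)CN1` gives 24000 nM
compound 3 `O=C(O)[C@H](CO)NC(=O)[C@H]1C[C@@H](O)CN1` gives 22700 nM

Compound 3 belongs to the upper pair of this small set. Inside that pair the numbers show a 1.1-fold lower number from compound 2 to compound 3 (0.02 log units; within the scatter), a change at a chain carbon. The clear gaps are a 6.0-fold higher number from compound 1 to compound 2 (0.78 log units; beyond the scatter) and a 5.7-fold higher number from compound 1 to compound 3 (0.75 log units; beyond the scatter). The second of these comes from configuration alone because of the fact that compounds 1 and 3 differ only in the configuration as drawn, and it involves a single stereocentre at a saturated ring carbon.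

The next compound is compound 4 `O=C(O)[C@H](CO)NC(=O)[C@@H]1C[C@H](O)CN1`, and the change from compound 3 is this: the two compounds have the same atoms and bonds and differ only in configuration as drawn: 2 of 3 stereo elements differ; a stereocentre at a saturated ring carbon is drawn R in compound 3 and S in compound 4; a stereocentre at a saturated ring carbon is drawn R in compound 3 and S in compound 4. Atoms and bonds stay the same, so only the ring stereocentres matter here. One of the two flips has a measured counterpart: a 5.7-fold higher number from compound 1 to compound 3 (0.75 log units; beyond the scatter), which, read backwards, points to a lower number. Among the measured compounds shown here, the second flip has no measured counterpart, so its size and direction are open.

A drop of similar size is therefore expected, with wide uncertainty, and the estimated change is a 4.5-fold lower number from compound 3 to compound 4 (0.66 log units; beyond the scatter). In this assay compound 4 is expected to give about 5000 nM, with an estimated range from 1200 nM to 22000 nM.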

Compound 4, maximal plasma concentration: 1050 nM
For compound 4 the middle estimate is 4.8-fold (0.68 log units) above the measured one; the measured number lies below the stated range.
By their numbers in this assay, from the lowest: compound 4; then compound 1; then compounds 3 and 2 (each within the scatter of the next).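

Among the compounds shown here, the second ring stereocentre, which had no measured counterpart before, now has one: a single flip gives a 3.8-fold lower number from compound 1 to compound 4 (0.58 log units; beyond the scatter) in this assay, so this flip also lowers the number on the way towards compound 4. For the compounds shown here, both ring flips therefore pull the same way, and a 22-fold lower number from compound 3 to compound 4 (1.33 log units; beyond the scatter) is about what a 5.7-fold higher number from compound 1 to compound 3 (0.75 log units; beyond the scatter), read backwards, and the single flip to compound 4 give when added together. Compound 2 and compound 4 are mirror images, and a 23-fold lower number from compound 2 to compound 4 (1.36 log units; beyond the scatter) shows that the number in the circulation can shift strongly with no change of atoms or bonds: the fact that compounds 2 and 4 differ only in the configuration as drawn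

On these data alone, the chain stereocentre is read only between compound 2 and compound 3, where the difference lies within the scatter, so it stays open whether it would matter as little with the ring stereocentres drawn as in compound 1 or compound 4. The compounds shown also do not tell why configuration moves the number, or what a methyl ester in place of the carboxylic acid would do to it.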